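From 4-cyanophenyl to thiophen-3-yl in the phenylsulfanyl series

This account rests on a few compounds, and the source may have more. Where it says the series, first, only, none or still open, it means among the compounds named here.

Three compounds share one core and differ in a single group on an aromatic carbon: compound 1 `Cc1ccc(-c2nc3ccccn3c2Sc2ccccc2)cc1`, compound 2 `CSc1ccc(-c2nc3ccccn3c2Sc2ccccc2)cc1` and compound 3 `N#Cc1ccc(-c2nc3ccccn3c2Sc2ccccc2)cc1`. Compound 1 gives only a limit in a functional assay on U-87MG ATCC cells for inhibition, with U-87 MG (Homo sapiens) as the target, read by MTT assay, with a stated time of 48 h (a lower number here means a stronger inhibitor, a higher number a weaker inhibitor), > 100000 nM. Compound 2 gives 26900 nM in this assay. Compound 3 gives 65500 nM, the higher of the two actual numbers.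

Methylsulfanyl in place of methyl gives an at least 3.7-fold lower number from compound 1 to compound 2 (0.57 log units; beyond the scatter). Cyano in place of methyl gives an at least 1.5-fold lower number from compound 1 to compound 3 (0.18 log units; that floor lies within the scatter). Cyano in place of methylsulfanyl gives a 2.4-fold higher number from compound 2 to compound 3 (0.39 log units; beyond the scatter).

Compound 4 `c1ccc(Sc2c(-c3ccsc3)nc3ccccn23)cc1` carries thiophen-3-yl in place of 4-cyanophenyl, on the aromatic carbon of the five-membered aromatic ring with 2 nitrogen: thiophen-3-yl in place of 4-cyanophenyl on an aromatic carbon. Among the measured compounds shown here, none of the measured steps replaces a whole aromatic group, so they bear on this change only indirectly. For the measured compounds named here, they show the span of the series, and the one step between two actual numbers, a 2.4-fold higher number from compound 2 to compound 3 (0.39 log units; beyond the scatter), is modest. No direction follows from them. The estimated step is a 1.3-fold lower number from compound 3 to compound 4 (0.12 log units; within the scatter), so no change beyond the scatter is expected. Compound 4 is estimated at 50000 nM, with an expected range of 18000 nM to 100000 nM.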

Compound 4, half-maximal inhibitory concentration: 58600 nM
For compound 4 the middle estimate is 1.2-fold (0.07 log units) below the measured one, and the stated range covers the measured number.
By their numbers in this assay, from the lowest: compound 2; then compounds 4 and 3 (each within the scatter of the next). At a limit, above all of these: compound 1.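

Swapping the whole aromatic group at this position, on an aromatic carbon of a five-membered aromatic ring with 2 nitrogen, gives no change that can be told apart in this assay (a 1.1-fold lower number from compound 3 to compound 4 (0.05 log units; within the scatter)), so a five-membered aromatic ring with 1 hetero atom stands in for the six-membered aromatic ring of carbon only, and the nitrile goes with it, without a shift beyond the scatter. Against the 4-(methylsulfanyl)phenyl group the same thiophen-3-yl is modestly weaker (a 2.2-fold higher number from compound 2 to compound 4 (0.34 log units; beyond the scatter)), which leaves compound 2 with the lowest number of the series, and a six-membered ring at this position is thus neither required nor, on these values, a disadvantage in itself. The step from the 4-methylphenyl group reads only as a floor (an at least 1.7-fold lower number from compound 1 to compound 4 (0.23 log units; that floor lies within the scatter)) and rests on a limit: the limit of > 100000 nM in this assay, at which 1 of the 4 values shown sits.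

All the actual numbers remain high, and the compounds shown do not say whether any group here can bring the number far below that of compound 2. An amine such as morpholin-4-yl or a carboxylic acid in place of thiophen-3-yl would test this position with something other than an aromatic ring.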